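A few compounds are considered here, and "the series" means these few. Any claim that something is new, unique, unknown or untested is made for them only; others in the source may bear on it.

Measured compounds in an assay for inhibition of inositol hexakisphosphate kinase 2 (Homo sapiens), read by colorimetric assay, coupled enzyme assay and malachite green, with a stated time of 120 min, in the presence of a further agent that is not named here; a higher number here means a weaker inhibitor, a lower number a stronger inhibitor:
- compound 1, `O=C(O)c1ccc2noc(-c3ccc(Oc4ccccn4)cc3)c2c1`: 1190 nM
- compound 2, `O=C(O)c1ccc2noc(-c3ccc(Oc4ncc(Cl)cc4Cl)cc3)c2c1`: 650 nM
- compound 3, `CC(C)C(=O)Nc1ccc(-c2onc3ccc(C(=O)O)cc23)cc1`: 820 nM

Compound 3 sits second highest of the three numbers in this assay. Its nearest neighbour is compound 2, with a 1.3-fold higher number from compound 2 to compound 3 (0.10 log units; within the scatter), and its furthest is compound 1, with a 1.5-fold lower number from compound 1 to compound 3 (0.16 log units; within the scatter); both gaps lie within the scatter, so the three compounds cannot be ordered on these data. The remaining step, a 1.8-fold lower number from compound 1 to compound 2 (0.26 log units; within the scatter), is also within the scatter.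

Compound 4, `O=C(O)c1ccc2noc(-c3ccc(N4CCCC4=O)cc3)c2c1`, differs from compound 3 in one place: 2-oxopyrrolidin-1-yl in place of (isopropylcarbonyl)amino on an aromatic carbon.

Among the compounds with values here, the steps that bear on this change are those at the same aromatic carbon, from compound 1 to compound 3 and from compound 2 to compound 3, where quite different groups were exchanged at that carbon with no movement beyond the scatter. The change to compound 4 keeps the heavy-atom count and the acceptor count at that position. On this basis no step beyond the scatter is expected in this assay, in either direction, and the estimated step is a 1.0-fold lower number from compound 3 to compound 4 (0.01 log units; within the scatter).

For compound 4 the number in this assay is expected to be 800 nM, within a range of 400 nM to 1600 nM.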

Compound 4, half-maximal inhibitory concentration: 480 nM
For compound 4 the middle estimate is 1.7-fold (0.22 log units) above the measured one; measured number inside the range.
By their numbers in this assay, from the lowest: compounds 4, 2, 3 and 1 (each within the scatter of the next, the first and the last beyond it).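

Notes on the aromatic carbon that carries the variable group, read in this assay: compound 4 replaces the open (isopropylcarbonyl)amino group with the ring of 2-oxopyrrolidin-1-yl, and the step stays within the scatter (a 1.7-fold lower number from compound 3 to compound 4 (0.23 log units; within the scatter)), so the hydrogen-bond donor of compound 3 is not required for inhibition at this level. Within the data shown here, the same group set against the aryl ethers gives a step within the scatter for one pair (a 1.4-fold lower number from compound 2 to compound 4 (0.13 log units; within the scatter)) and, for the other, the first step beyond the scatter, though only a modest one (a 2.5-fold lower number from compound 1 to compound 4 (0.39 log units; beyond the scatter)), so this position now shows a measurable difference, confined to that single pair. No measurement here bears on the origin of any of these steps.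

The compounds shown leave open whether the ring or the loss of the amide hydrogen matters more, a question that a methyl group on the amide nitrogen of compound 3 would separate, and whether a six-membered lactam such as piperidin-2-one would behave like 2-oxopyrrolidin-1-yl. They also leave open how far these readings depend on the carboxylic acid of the shared core, which a tetrazole or a methyl ester in its place would test.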